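The source may report more compounds than this note shows. Statements on the series, on what has been measured and on what is new or still open speak of the compounds shown alone.

Of the compounds shown here, three share one core and have been tested in a functional assay for inhibition, tested at 80 ug/mL; on this read-out lower numbers stand for a weaker effect and higher numbers for a stronger effect at the one concentration tested. Compound 3 `COc1ccc(-c2cc(-c3cc(C(C)C)c(O)cc3C)[nH]c(=O)c2C#N)cc1OC` gives 58% in this assay, the second highest of the three numbers. Compound 2 `Cc1cc(O)c(C(C)C)cc1-c1cc(-c2ccco2)c(C#N)c(=O)[nH]1` gives 64%, and the difference from compound 2 to compound 3 is a number 6 percentage points lower from compound 2 to compound 3 (within the scatter), so the two cannot be told apart. Compound 1 `COc1ccc(-c2cc(-c3cc(C(C)C)c(O)cc3C)[nH]c(=O)c2C#N)cc1` gives 47.5%; the step from compound 1 to compound 3 is a number 10.5 percentage points higher from compound 1 to compound 3 (beyond the scatter), and the step from compound 1 to compound 2 is a number 16.5 percentage points higher from compound 1 to compound 2 (beyond the scatter).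

Compound 4 `Cc1cc(O)c(C(C)C)cc1-c1cc(-c2ccccc2Cl)c(C#N)c(=O)[nH]1` differs from compound 3 by 2-chlorophenyl in place of 3,4-dimethoxyphenyl on an aromatic carbon. All three measured steps concern exchanges at or on the aromatic group at this very carbon, and none of them moved the read-out by more than a modest amount. Going by the values given here, no measured compound carries 2-chlorophenyl, so the direction cannot be read from the data. The step from compound 3 to compound 4 is expected to be a number 8 percentage points lower from compound 3 to compound 4 (within the scatter), a shift of little more than the scatter. Compound 4 is therefore estimated to give 50% in this assay, most likely between 30% and 70%.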

Compound 4, a percentage reported as inhibition, at one concentration (the size of the read-out at that concentration, not a potency): 32%
Beside the measured number, compound 4's estimate is 18 percentage points above it; low and high end bracket the measured number.
By their numbers in this assay, from the lowest: compound 4; then compound 1; then compounds 3 and 2 (each within the scatter of the next).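

Putting 2-chlorophenyl on this carbon in this assay gives a number 26 percentage points lower from compound 3 to compound 4 (beyond the scatter) against 3,4-dimethoxyphenyl, a number 32 percentage points lower from compound 2 to compound 4 (beyond the scatter) against furan-2-yl and a number 15.5 percentage points lower from compound 1 to compound 4 (beyond the scatter) against 4-methoxyphenyl. The earlier exchanges at this carbon showed only furan-2-yl and 3,4-dimethoxyphenyl standing above 4-methoxyphenyl, whereas compound 4 now falls clearly below all three other compounds, so the choice of aromatic group here can lower the number as well as raise it. Nothing measured here explains this drop.

On these data alone, how plain phenyl or 4-chlorophenyl would read at this carbon stays open, so it is unclear whether the drop goes with the chlorine itself or with where it sits on the ring. Equally open, as far as these compounds go, is how a group that is not an aromatic ring, such as a carboxylic acid or an amine, would read here.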